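Series notes: cyclopentyl in place of butyl

The source may report more compounds than this note shows. Statements on the series, on what has been measured and on what is new or still open speak of the compounds shown alone.

Compound 1 `COC(=O)c1nc(C)n(-c2ccccc2C(F)(F)F)n1` gives > 100000 nM in a functional assay on Jurkat cells (Homo sapiens) for inhibition, read by MTT assay, with a stated time of 72 h (on this read-out higher numbers stand for weaker inhibition of growth and lower numbers for stronger inhibition of growth), a limit of the assay and not a number.
Compound 2 `COC(=O)c1nc(C)n(-c2ccc(F)cc2)n1` gives 8700 nM in this assay.
Compound 3 `CCCCc1nc(C(=O)OC)nn1-c1ccc(F)cc1` gives > 100000 nM in this assay, again a limit and not a number.

Compound 3 therefore stands at the weak end of what is shown: its value is only a limit, and it sits at the limit of > 100000 nM in this assay, at which 2 of the 3 values shown sit. Among the compounds with values here, the one measured step that reaches compound 3 is an at least 11-fold higher number from compound 2 to compound 3 (1.06 log units; beyond the scatter), so adding chain bulk at this position of the shared core moved the read-out from a measured number to the limit.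

Compound 4 `COC(=O)c1nc(C2CCCC2)n(-c2ccc(F)cc2)n1` is not yet measured. It differs from compound 3 by cyclopentyl in place of butyl on an aromatic carbon. Within the data shown here, no measured step exchanges one saturated carbon group for another of similar size at this position, so the only guidance is that compound 3 already sits at the limit. The expectation for a number no higher from compound 3 to compound 4 (the limit leaves the size open) is accordingly no change beyond the scatter, with compound 4 most likely reported again as a limit. Compound 4 is estimated at 100000 nM, in the range 30000 nM to 300000 nM.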

Compound 4, concentration for 50% growth inhibition: 9550 nM
For compound 4 the middle estimate is 10-fold (1.02 log units) above the measured one; measured number below the stated range.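

Cyclopentyl in place of butyl gives an at least 10-fold lower number from compound 3 to compound 4 (1.01 log units; beyond the scatter) in this assay, though the true size of this step stays open, as the value of compound 3 is a limit and not a number. Cyclopentyl in place of methyl gives a 1.1-fold higher number from compound 2 to compound 4 (0.04 log units; within the scatter), so the larger group alone does not carry the read-out to the limit, and among the three groups shown on this aromatic carbon only butyl does so. The limit therefore belongs to particular groups and not to size as such: the limit of > 100000 nM in this assay, at which 2 of the 4 values shown sit.

On these data alone, whether the ring, the branching or the chain length decides the outcome stays open, and isopropyl, propyl or cyclohexyl on this carbon would separate these. Also open, as far as these compounds go, is how an amine or a carboxylic acid would read here.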